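Swapping a Dichlorophenyl Ring for a Chlorothiophene

The source may report more compounds than this note shows. Statements on the series, on what has been measured and on what is new or still open speak of the compounds shown alone.

The three compounds measured here share a core in which a carbon-nitrogen double bond carries two benzyl groups on the nitrogen, and they differ in the group attached to that carbon. Compound 1, `COc1ccc2c(c1)CCC/C2=N\N(Cc1ccccc1)Cc1ccccc1`, reaches only a limit in an assay on liver (Sus scrofa) for inhibition of glucose-6-phosphatase catalytic subunit 1 (Homo sapiens), using microsomes (on this read-out lower numbers stand for stronger inhibition and higher numbers for weaker inhibition), giving > 50000 nM. Compound 2, `CN(C)c1ccc(/C=N/N(Cc2ccccc2)Cc2ccccc2)cc1`, gives 100000 nM in this assay. Compound 3, `Clc1cc(Cl)cc(/C=N/N(Cc2ccccc2)Cc2ccccc2)c1`, gives > 100000 nM in this assay, which is a limit rather than a number. Compound 3 thus stands at a limit of what this assay can report, as does compound 1 (the limit of > 50000 nM in this assay, at which 1 of the 3 values shown sits), and compound 2 sits close to that region. Among the compounds with values here, no step between two measured compounds that differ in a single place is available.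

Compound 4, `Clc1ccc(/C=N/N(Cc2ccccc2)Cc2ccccc2)s1`, differs from compound 3 by 5-chlorothiophen-2-yl in place of 3,5-dichlorophenyl on a carbon with a double bond to nitrogen. Since all three measured compounds sit at or near the limit of this assay, and compound 3 itself sits at the limit (the limit of > 100000 nM in this assay, at which 1 of the 3 values shown sits), the change to compound 4 is expected to give no step beyond the usual scatter in either direction, so the estimated step of a number no higher from compound 3 to compound 4 (the limit leaves the size open) is small. Compound 4 is therefore expected to give about 100000 nM, within 30000 nM to 300000 nM, and most likely the assay would again report only a limit.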

Compound 4, half-maximal inhibitory concentration: 170 nM
Compound 4: the middle estimate sits 590-fold (2.77 log units) above what was measured; measured number outside the range, below it.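

Exchanging 3,5-dichlorophenyl for 5-chlorothiophen-2-yl on a carbon with a double bond to nitrogen gives, in this assay, an at least 580-fold lower number from compound 3 to compound 4 (2.76 log units; beyond the scatter), so the group at this position can separate a compound with no measurable inhibition from one that is readily measured. The earlier compounds shown here offered no pair differing in one place, so they could not show that this group matters so strongly, or that the shared core can carry strong inhibition at all. The true size of the step remains unknown because compound 3 is reported only as a limit, not as a number: the limit of > 100000 nM in this assay, at which 1 of the 4 values shown sits.

This single exchange alters the ring size, brings in sulfur and changes the number of chlorine atoms all at once, so the compounds shown cannot say which of these differences accounts for the step, or why it is so large. A thiophen-2-yl ring without chlorine and a phenyl ring carrying one chlorine would help pull these differences apart, while a bromine or methyl group in place of the chlorine on the thiophene would test whether that atom is needed.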